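The compounds below may be only part of what the source reports. "The series", "measured", "known", "first", "only" and "open" are said of these compounds alone.

In an ADME assay on BJ cells (Homo sapiens) for cytotoxicity, with a stated time of 72 h; a higher number here means that more compound is needed for the effect, a lower number that less compound is needed:
compound 1 `CCc1ccc(-c2nc3c(c(C)nn3-c3ccccc3)c(-c3ccccc3O)c2C#N)cc1`: > 20000 nM, a limit
compound 2 `CCCc1ccc(-c2nc3c(c(C)nn3-c3ccccc3)c(-c3ccccc3O)c2C#N)cc1`: 22500 nM
compound 3 `CCc1ccc(-c2nc3c(c(-c4ccccc4)nn3-c3ccccc3)c(-c3ccccc3O)c2C#N)cc1`: > 20000 nM, a limit

Compound 3 gives > 20000 nM, which is a limit and not a number. Its position is shared with one other compound of the three: the limit of > 20000 nM in this assay, at which 2 of the 3 values shown sit. Among the compounds with values here, compound 2 gives 22500 nM, the only true number in the set.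

The next compound is compound 4 `CCc1ccc(-c2nc3c(c(C4CC4)nn3-c3ccccc3)c(-c3ccccc3O)c2C#N)cc1`, which differs from compound 3 as follows: cyclopropyl in place of phenyl on an aromatic carbon. In words, it has cyclopropyl in place of phenyl on an aromatic carbon.

The closest measured change is at the same aromatic carbon, phenyl in place of methyl: a step that the two limits leave unreadable from compound 1 to compound 3. Its size cannot be read. The other measured change lies on the saturated chain: a step that the limit leaves unreadable from compound 1 to compound 2. Its size cannot be read either. Neither therefore gives a measured size to carry over. With methyl and phenyl at this carbon both ending at a limit, no step beyond the usual scatter is expected in this assay, and no direction is expected. The estimated change is a step that the limit leaves unreadable from compound 3 to compound 4. A reading at the limit is also quite likely.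

For compound 4 the expected value is 22000 nM, with an estimated range of 12000 nM to 40000 nM.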

Compound 4, half-maximal effective concentration in the BJ assay: > 20000 nM
Compound 4: no number, only a limit; the forecaster's own chance of this, stated with the estimate: 65%; the middle value lies beyond the limit too.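

In the BJ assay compound 4 gives > 20000 nM, a limit and not a number. No new step can be read between compound 4 and compound 1 or compound 3, and the three share one limit: the limit of > 20000 nM in the BJ assay, at which 3 of the 4 values shown sit.

In a physicochemical assay for solubility, read by spectrophotometry, in phosphate buffer, with a stated time of 18 h, at pH 7.4 (on this read-out higher numbers stand for higher solubility and lower numbers for lower solubility), compound 3 gives 30000 nM and compound 4 gives 21000 nM. In the physicochemical assay this is a 1.4-fold lower number from compound 3 to compound 4 (0.15 log units; within the scatter).

The compounds shown leave open whether methyl, phenyl and cyclopropyl on this aromatic carbon differ at all in the BJ assay.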